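Chloro in Place of Methoxy on Two Related Cores

The source may hold more compounds than are shown below. What is called first, only, known or untested is meant among the compounds shown, and "the series" means these compounds.

Compound 1 `Cc1ccc(S(=O)(=O)Oc2ccc3c(c2C)[C@H](Cn2cc(-c4ccc(Cl)cc4)nn2)[C@@]24CC(=O)[C@@](C)(CC[C@@H]32)C4)cc1`: in a functional assay on SW480 cells (Homo sapiens) for cytotoxicity, read by MTT assay, with a stated time of 4 days (on this read-out higher numbers stand for weaker inhibition and lower numbers for stronger inhibition), compound 1 gives > 20000 nM, a limit of the assay.
Compound 2 `C=C1C[C@]23C[C@@]1(O)CC[C@@H]2c1cccc(C)c1[C@@H]3Cn1cc(-c2ccc(OC)cc2)nn1`: in this assay compound 2 gives > 20000 nM, a limit of the assay.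
Compound 3 `COc1ccc(-c2cn(C[C@H]3c4c(ccc(OS(=O)(=O)c5ccc(C)cc5)c4C)[C@@H]4CC[C@@]5(C)C[C@]43CC5=O)nn2)cc1`: in this assay compound 3 gives > 20000 nM, a limit of the assay.

Of the compounds shown here, three have been measured, and none of them gives a number: all three sit at the limit of > 20000 nM in this assay, at which 3 of the 3 values shown sit. Compound 3 and compound 1 differ in one place only, by chloro in place of methoxy on an aromatic carbon. Both of them stop at the limit. The step that the two limits leave unreadable from compound 3 to compound 1 therefore cannot be sized in either direction.

Compound 2 carries a different core; the difference between the core of compound 2 and the core of compound 3 is not broken down here. Compound 4 `C=C1C[C@]23C[C@@]1(O)CC[C@@H]2c1cccc(C)c1[C@@H]3Cn1cc(-c2ccc(Cl)cc2)nn1` is the unmeasured partner of compound 2, and it differs from compound 2 by chloro in place of methoxy on an aromatic carbon, the same change, at the same kind of place, as from compound 3 to compound 1.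

The measured pair gives no readable size for that change, so the expectation for compound 4 rests on compound 2 alone, whose value > 20000 nM is a limit. The step that the limit leaves unreadable from compound 2 to compound 4 is therefore expected to be small, with compound 4 most likely also ending at the limit. The estimate for compound 4 is 30000 nM, with a plausible span from 8000 nM to 120000 nM.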

Compound 4, half-maximal inhibitory concentration: > 20000 nM
Compound 4 ended at the assay's limit; the forecaster's own chance of this, stated with the estimate: 85%; the middle value does not contradict the limit.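

Compound 2 and compound 4 both stop at a limit of the assay rather than at a number, so no size can be read for the change from methoxy to chloro between them: the limit of > 20000 nM in this assay, at which 4 of the 4 values shown sit.

The compounds shown leave open whether chloro in place of methoxy makes any difference at all in this assay, and which structural change would bring a compound to a readable number there.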